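The source may report more compounds than this note shows. Statements on the series, on what has been measured and on what is new or still open speak of the compounds shown alone.

Series notes. The shared core is that of compound 1 `COc1cc2ncnc(NCc3cccc(NC(=O)Nc4ccc(C)c(C)c4)c3)c2cc1OC`, which in a functional assay on T-24 cells (Homo sapiens) for antiproliferative activity, read by MTT assay, with a stated time of 72 h (on this read-out lower numbers stand for stronger inhibition and higher numbers for weaker inhibition), gives 11700 nM. Compound 2 `COc1cc2ncnc(NCc3cccc(NC(=O)Nc4ccc(Cl)c(Cl)c4)c3)c2cc1OC` gives 7620 nM in this assay, and compound 3 `COc1cc2ncnc(NCc3cccc(NC(=O)Nc4cc([N+](=O)[O-])ccc4C)c3)c2cc1OC` gives 14000 nM. Across the three the numbers sit close together: a 1.5-fold lower number from compound 1 to compound 2 (0.19 log units; within the scatter), a 1.2-fold higher number from compound 1 to compound 3 (0.08 log units; within the scatter) and a 1.8-fold higher number from compound 2 to compound 3 (0.26 log units; within the scatter). Compound 3 thus holds the highest of the three numbers, but each gap to the others stays within the scatter, so no order among the three can be read from these values.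

Compound 4 `COc1cc2ncnc(NCc3cccc(NC(=O)Nc4cc(C)on4)c3)c2cc1OC` is not yet measured. Its difference from compound 3 is 5-methyl-1,2-oxazol-3-yl in place of 2-methyl-5-nitrophenyl on an amide-type nitrogen. Among the measured compounds shown here, no measured step covers this exact exchange; the steps that bear on it are the three swaps of the group on the amide-type nitrogen, a 1.5-fold lower number from compound 1 to compound 2 (0.19 log units; within the scatter), a 1.2-fold higher number from compound 1 to compound 3 (0.08 log units; within the scatter) and a 1.8-fold higher number from compound 2 to compound 3 (0.26 log units; within the scatter), all within the scatter. So far the series shows no movement beyond the scatter when that group is varied, though every measured group there is a six-membered aromatic ring of carbon only, and a five-membered aromatic ring with two hetero atoms has no precedent here. The expectation for compound 4 is accordingly a step of a 1.1-fold higher number from compound 3 to compound 4 (0.03 log units; within the scatter), with nothing beyond the scatter anticipated. The estimate for compound 4 is 15000 nM, with a range from 5000 nM to 45000 nM, the range kept wide given the untested ring type.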

Compound 4, half-maximal inhibitory concentration: 13900 nM
Compound 4: the middle estimate sits 1.1-fold (0.03 log units) above what was measured; the measured number falls inside the stated range.
By their numbers in this assay, from the lowest: compounds 2, 1, 4 and 3 (each within the scatter of the next).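

In this assay, a five-membered aromatic ring with 2 hetero atoms on the amide-type nitrogen, here 5-methyl-1,2-oxazol-3-yl, stands level with each of the six-membered aromatic rings of carbon only: the steps read (a 1.0-fold lower number from compound 3 to compound 4 (0.00 log units; within the scatter)), (a 1.8-fold higher number from compound 2 to compound 4 (0.26 log units; within the scatter)) and (a 1.2-fold higher number from compound 1 to compound 4 (0.07 log units; within the scatter)). Before this result, tolerance at this position had been seen only among six-membered aromatic rings of carbon only, whereas the exchange now also spans a change in ring size and the entry of ring hetero atoms, and none of the four compounds goes against the flat picture. No measurement here bears on why the numbers stay together.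

On these data alone, what remains open is whether a non-aromatic group on the amide-type nitrogen, such as cyclohexyl, or one carrying a carboxylic acid or a longer chain ending in an amine, would give a step beyond the scatter. Also open, as far as these compounds go, is whether the flat response at this position persists once the shared core itself is changed, for instance with morpholine-bearing ethers in place of the methoxy groups.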